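From dimethoxyphenyl to bromophenyl on a carbonyl carbon

The source may report more compounds than this note shows. Statements on the series, on what has been measured and on what is new or still open speak of the compounds shown alone.

In a functional assay on MCF7 cells (Homo sapiens) for inhibition, read by MTT assay, with a stated time of 24 h (on this read-out lower numbers stand for stronger inhibition of growth and higher numbers for weaker inhibition of growth), compound 3 `COc1ccc2c(c1)c(-c1nc3ccccc3n1C(=O)c1ccc(OC)c(OC)c1)cn2C` gives 6300 nM as the lowest of three numbers, against compound 2 `COc1ccc(C(=O)n2c(-c3cn(C)c4ccc(OC)cc34)nc3ccccc32)cc1` at 14800 nM and compound 1 `COc1ccc2c(c1)c(-c1nc3ccccc3n1C(=O)c1ccccc1)cn2C` at 38400 nM on the same scale. Compound 4 `COc1ccc2c(c1)c(-c1nc3ccccc3n1C(=O)c1ccccc1Br)cn2C` has 2-bromophenyl in place of 3,4-dimethoxyphenyl on a carbonyl carbon and is still unmeasured. Methoxy in place of hydrogen on an aromatic carbon came with a 2.6-fold lower number from compound 1 to compound 2 (0.41 log units; beyond the scatter) and then a 2.3-fold lower number from compound 2 to compound 3 (0.37 log units; beyond the scatter) in these compounds. Among the measured compounds shown here, compound 4 lacks methoxy, and no measured compound holds bromine, so the best guide is a 6.1-fold lower number from compound 1 to compound 3 (0.78 log units; beyond the scatter) read in reverse. A modest change is therefore expected in this assay as a 2.9-fold higher number from compound 3 to compound 4 (0.46 log units; beyond the scatter) towards weaker inhibition of growth. Compound 4 is estimated at 18000 nM within a range of 6000 nM to 50000 nM on this read-out.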

Compound 4, concentration for 50% growth inhibition: 55800 nM
Compound 4: middle estimate off by 3.1-fold (0.49 log units), on the low side, and the stated range ends below it.
By their numbers in this assay, from the lowest: compound 3; then compound 2; then compounds 1 and 4 (each within the scatter of the next).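

In this assay, swapping in 2-bromophenyl on the carbonyl carbon gives an 8.9-fold higher number from compound 3 to compound 4 (0.95 log units; beyond the scatter) and, against 4-methoxyphenyl, a 3.8-fold higher number from compound 2 to compound 4 (0.58 log units; beyond the scatter) on this position. Bromo in place of hydrogen on an aromatic carbon gives a 1.5-fold higher number from compound 1 to compound 4 (0.16 log units; within the scatter) and so stays within the scatter, unlike the methoxy steps to compound 2 and compound 3. At this position, then, the one bromine shown does not match what methoxy did.

No measured property here explains these steps. Still open, from the compounds shown here alone, is how an amine or a carboxylic acid would read on this aromatic ring.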